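The source may hold more compounds than are shown below. What is called first, only, known or untested is meant among the compounds shown, and "the series" means these compounds.

Compound 1 `CC(C)(C)c1ccc(C(=O)N2CCC3(CC2)C(=O)N(CC(=O)NCCCCCNS(C)(=O)=O)CN3c2ccccc2)cc1` is the starting point. In an assay on HEK293 cells for displacement of a labelled ligand from NPC1-like intracellular cholesterol transporter 1 (Homo sapiens) (a higher number here means a weaker inhibitor, a lower number a stronger inhibitor), compound 1 gives 5500 nM, the second highest of the three numbers in hand. Its nearest neighbour is compound 3 `O=C(CN1CN(c2ccccc2)C2(CCN(C(=O)c3ccc(C4CCCCC4)cc3)CC2)C1=O)NCO`, which in this assay gives 8300 nM, a gap within the scatter. Furthest away is compound 2 `O=C(CN1CN(c2ccccc2)C2(CCN(C(=O)c3ccc(C4CCCCC4)cc3)CC2)C1=O)N1CCCCC1`, which in this assay gives 1100 nM, a gap beyond the scatter. Within the data shown here, the only single-point step in the set is a 7.5-fold higher number from compound 2 to compound 3 (0.88 log units; beyond the scatter); it concerns the group on the carbonyl carbon and leaves the sulfonamide-bearing chain untouched, so it does not bear on the change now at hand.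

Compound 4 `CC(C)(C)c1ccc(C(=O)N2CCC3(CC2)C(=O)N(CC(=O)NCCCCNS(C)(=O)=O)CN3c2ccccc2)cc1` is the next compound. It differs from compound 1 as follows: methanesulfonamido in place of (methanesulfonamido)methyl on a saturated chain carbon, four bonds along the chain from an amide-type nitrogen The chain is cut shorter while the methanesulfonamido end, with its hydrogen-bond donor and two hydrogen-bond acceptors, is kept. Among the measured compounds shown here, no measured pair in the set alters this chain, so nothing fixes the size of the effect. With the rest of the structure held constant, the expectation for this assay is a step of no more than the scatter, in either direction, namely a 1.1-fold lower number from compound 1 to compound 4 (0.04 log units; within the scatter). Compound 4 is therefore expected to give about 5000 nM in this assay, within a range of 2300 nM to 11000 nM.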

Compound 4, half-maximal inhibitory concentration: 4500 nM
For compound 4 the middle estimate is 1.1-fold (0.05 log units) above the measured one, within the range that was stated.
By their numbers in this assay, from the lowest: compound 2; then compounds 4, 1 and 3 (each within the scatter of the next).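

Among these compounds, the first pair to alter the sulfonamide-bearing chain gives, in this assay, a 1.2-fold lower number from compound 1 to compound 4 (0.09 log units; within the scatter). On this saturated chain, four bonds along from an amide-type nitrogen, methanesulfonamido in place of (methanesulfonamido)methyl therefore leaves the number within the scatter, with the rest of the structure held constant and the methanesulfonamido end kept. This is a single pair and sets no trend in chain length, and no supporting data bear on why the two compounds fall so close.

From the compounds shown here alone, it remains open whether a much shorter chain, such as 2-(methanesulfonamido)ethyl, or a longer chain than that of compound 1 would also stay within the scatter of these two compounds. Also open, going by these compounds, is whether the number depends on the methanesulfonamido end itself, which a carboxylic acid or a primary amine at the end of the same chain would test.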